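Removing the chloro from a set of inactive compounds

The source may hold more compounds than are shown below. What is called first, only, known or untested is meant among the compounds shown, and "the series" means these compounds.

Compound 3 `O=c1ccoc2cc(OCc3cn(Cc4ccc(Cl)cc4)nn3)ccc12` was tested in a functional assay on A549 cells (Homo sapiens) for cytotoxicity, read by MTT assay, with a stated time of 48 h; on this read-out lower numbers stand for stronger inhibition and higher numbers for weaker inhibition. In this assay compound 3 gives > 100000 nM, a limit of the assay rather than a number. Its relatives share this outcome: compound 1 `O=c1ccoc2cc(OCc3cn(Cc4ccc([N+](=O)[O-])cc4)nn3)ccc12` gives > 100000 nM, also a limit, in this assay. Compound 2 `O=c1ccoc2cc(OCc3cn(Cc4ccccc4Br)nn3)ccc12` likewise gives > 100000 nM, a limit, in this assay. The steps a step that the two limits leave unreadable from compound 1 to compound 2, a step that the two limits leave unreadable from compound 1 to compound 3 and a step that the two limits leave unreadable from compound 2 to compound 3 therefore have no readable size, since (the limit of > 100000 nM in this assay, at which 3 of the 3 values shown sit). Compound 4 `O=c1ccoc2cc(OCc3cn(Cc4ccccc4)nn3)ccc12` differs from compound 3 by hydrogen in place of chloro on an aromatic carbon. With no readable step to lean on, the expected step that the limit leaves unreadable from compound 3 to compound 4 has no direction that can be read, and a further limit is the most likely result. Compound 4 is estimated at 150000 nM in this assay, between 40000 nM and 500000 nM.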

Compound 4, half-maximal inhibitory concentration: > 100000 nM
Compound 4: no number, only a limit (the forecaster's own chance of this, stated with the estimate: 85%); the middle value lies beyond the limit too.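

Among the compounds shown here, no step from compound 1, compound 2 or compound 3 to compound 4 can be read, because all four compounds end at the same limit: the limit of > 100000 nM in this assay, at which 4 of the 4 values shown sit. The compounds shown leave open how far beyond that limit each lies, and so whether exchanging these groups changes anything.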